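This account rests on a few compounds, and the source may have more. Where it says the series, first, only, none or still open, it means among the compounds named here.

Compound 1 `Cc1c(C(=O)Nc2ccc(Oc3ccnc4[nH]ccc34)c(F)c2)nnn1-c1ccccc1` and compound 2 `Cc1c(C(=O)Nc2ccc(Oc3ccnc4[nH]ccc34)cc2)nnn1-c1ccccc1F` are built from the same atoms joined differently; the difference between the two cores is not broken down here. In a functional assay on A549 cells (Homo sapiens) for cytotoxicity, read by MTT assay, with a stated time of 72 h (a higher number here means a weaker inhibitor, a lower number a stronger inhibitor), compound 1 gives 360 nM, and compound 2 gives 320 nM. Compound 3 `O=C(Nc1ccc(Oc2ccnc3[nH]ccc23)c(F)c1)c1nnn(-c2ccccc2)c1C(F)(F)F` carries trifluoromethyl in place of methyl on an aromatic carbon on the core of compound 1, which made a 1.6-fold lower number from compound 1 to compound 3 (0.21 log units; within the scatter). Compound 4 `O=C(Nc1ccc(Oc2ccnc3[nH]ccc23)cc1)c1nnn(-c2ccccc2F)c1C(F)(F)F` carries the same kind of change, (trifluoromethyl in place of methyl on an aromatic carbon), on the core of compound 2; around the place, the ring atom that bears a 2-fluorophenyl group (7 heavy atoms) stands where compound 1 has the ring atom that bears a phenyl group (6 heavy atoms). Because compound 3 gives 220 nM after that change, compound 4 is expected to show a 1.6-fold lower number from compound 2 to compound 4 (0.20 log units; within the scatter) in this assay. Its estimated value for compound 4 is 200 nM, expected to fall between 100 nM and 450 nM.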

Compound 4, half-maximal inhibitory concentration: 210 nM
Estimate against measurement, compound 4: 1.1-fold (0.02 log units) below, within the range that was stated.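

In this assay putting trifluoromethyl in place of methyl gives a 1.5-fold lower number from compound 2 to compound 4 (0.18 log units; within the scatter) and, set beside the earlier step, the change reads much the same on both cores: the same change on two cores in this assay, a 1.6-fold lower number (0.21 log units; within the scatter) from compound 1 to compound 3 and a 1.5-fold lower number (0.18 log units; within the scatter) from compound 2 to compound 4, 1.1-fold (0.03 log units) apart, within the scatter of two such steps. Each step lies within the scatter, so the pair shows that the change carries from one core to the other with no visible difference in this read-out, but it does not show that trifluoromethyl makes these compounds stronger inhibitors. Two cores are also a small sample, and they say nothing about how the change would read on any other core in the series.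

The compounds shown leave open whether a different group in that place, such as an amine, a carboxylic acid or a longer chain, would move the number beyond the scatter. They also leave open how this change would read on cells other than the ones tested here.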